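This account rests on a few compounds, and the source may have more. Where it says the series, first, only, none or still open, it means among the compounds named here.

Three compounds have been measured in a functional assay on EL4 cells (Mus musculus) for inhibition, tested at 100 uM; on this read-out lower numbers stand for less inhibition and higher numbers for more inhibition at the one concentration tested (going by the name of the read-out):
Compound 1 `OC[C@H]1OC(n2cnc3c(Nc4ccccc4)nccc32)[C@H](O)[C@@H]1O` gives 10%.
Compound 2 `OC[C@H]1O[C@@H](n2cnc3c(NCc4ccccc4)nccc32)C[C@@H]1O` gives 8%.
Compound 3 `CNc1[nH]ccc2ncnc1-2` gives only a limit of the assay, < 5%.

All three results are modest for a test at a single, high concentration, so none of these compounds inhibits strongly. Compound 1 is one of the two compounds that return a number rather than a limit, and the value of compound 2 lies within the usual scatter of repeated measurements of it, so the two cannot be told apart. For compound 3 the read-out sits at the limit of this assay, as the limit of < 5% in this assay, at which 1 of the 3 values shown sits, records.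

The untested compound 4 `[N-]=[N+]=Nc1nccc2c1ncn2C1O[C@H](CO)[C@@H](O)[C@H]1O` differs from compound 1 in one place: azido in place of anilino on an aromatic carbon. The change removes a group carrying a six-membered aromatic ring of carbon only and puts in an azido group with no ring. Among the measured compounds shown here, no pair of measured compounds differs by a single change, so no measured step exists to guide the size of this one. With every measured compound giving a low read-out, the step in this assay is expected to stay within the scatter, in either direction. Compound 4 is therefore estimated at 8%, with a range from 0% to 20%. The expected step is a number 2 percentage points lower from compound 1 to compound 4 (within the scatter).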

Compound 4, a percentage reported as inhibition, at one concentration (the size of the read-out at that concentration, not a potency): < 5%
Compound 4: a limit, no number; the forecaster's own chance of this, stated with the estimate: 30%; at least 3 percentage points between middle value and limit.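

Among the compounds shown here, this is the first measured single change in the set. In this assay, putting azido in place of anilino on the aromatic carbon next to the ring nitrogen gives a number at least 5 percentage points lower from compound 1 to compound 4 (that floor lies within the scatter); the step therefore shows that the six-membered aromatic ring of carbon only can leave this position without any rise in the read-out, but it does not show a drop larger than the scatter. Compound 4 gives < 5%, which is a limit of the assay and not a number, so its true distance from compound 1 stays unknown, and the read-out has little room left at this low end: the limit of < 5% in this assay, at which 2 of the 4 values shown sit.

The compounds shown leave open whether any group at this position can lift inhibition clearly above the scatter, for instance a simple primary amine, a methoxy group or a longer alkyl chain in place of anilino on the core of compound 1. They also leave open whether anilino itself adds anything to the small read-out of compound 1, as one azido compound at the limit cannot settle that.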